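Trifluoromethyl to tert-butyl: a step from three limits

A few compounds are considered here, and "the series" means these few. Any claim that something is new, unique, unknown or untested is made for them only; others in the source may bear on it.

Values so far in a physicochemical assay for lipophilicity, at pH 7.4 (on this read-out higher numbers stand for higher lipophilicity and lower numbers for lower lipophilicity), are limits, not numbers:
Compound 1 `Cc1ccc(CNCCCC[C@@H](Nc2cc(C)c(F)c(C)c2)C(=O)NO)cc1` gives < 3 as a limit
Compound 2 `COc1ccc(CNCCCC[C@@H](Nc2cc(C)c(F)c(C)c2)C(=O)NO)cc1` gives < 3 as a limit
Compound 3 `Cc1cc(N[C@H](CCCCNCc2ccc(C(F)(F)F)cc2)C(=O)NO)cc(C)c1F` gives < 3 as a limit

From the compounds shown here alone, compound 3 therefore stands at < 3 in this assay and this is a limit, so its true position is unknown. Compound 4 `Cc1cc(N[C@H](CCCCNCc2ccc(C(C)(C)C)cc2)C(=O)NO)cc(C)c1F` differs from it by one exchange tert-butyl in place of trifluoromethyl on an aromatic carbon with tert-butyl in place of trifluoromethyl on an aromatic carbon, para to a large group.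

Among the measured compounds shown here, three measured steps bear on this exchange, each swapping one group on an aromatic carbon. They are the step that the two limits leave unreadable from compound 1 to compound 2 and the step that the two limits leave unreadable from compound 1 to compound 3 and the step that the two limits leave unreadable from compound 2 to compound 3 and none has a readable size. For the measured compounds named here, the only evidence is the limit of < 3 in this assay, at which 3 of the 3 values shown sit, and it offers no size or direction to carry over. No step beyond the usual scatter can therefore be expected from these data. The expected change is a step that the limit leaves unreadable from compound 3 to compound 4 as an estimate only. The estimate for compound 4 is 2.8 with an expected range from 2.2 to 3.4 and a limit rather than a number is quite possible.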

Compound 4, distribution coefficient: < 3
Compound 4: only a limit was reported (the forecaster's own chance of this, stated with the estimate: 60%); the middle value is on the limit's open side.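

In this assay compound 4 gives < 3, which is a limit and not a number. Its steps from compound 1, compound 2 and compound 3 therefore cannot be read: the limit of < 3 in this assay, at which 4 of the 4 values shown sit. From the compounds shown here alone, how far apart these four compounds truly lie on this read-out, and in what order, stays open.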